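The source may report more compounds than this note shows. Statements on the series, on what has been measured and on what is new or still open speak of the compounds shown alone.

In a functional assay on Caov-3 cells (Homo sapiens) for antiproliferative activity, read by CellTiter-Glo, with a stated time of 96 h (a lower number here means a stronger inhibitor, a higher number a weaker inhibitor), compound 1, `COc1ccc(-c2nsc3c2NC(=O)CC3c2cccc(OC)c2)cc1`, gives 1480 nM, and compound 2, `COc1ccc(-c2nsc3c2NC(=O)CC3c2cccc(Cl)c2)cc1`, gives 1300 nM. The two differ by chloro in place of methoxy on an aromatic carbon, and the step of a 1.1-fold lower number from compound 1 to compound 2 (0.06 log units; within the scatter) shows the two numbers within the usual scatter of each other. Compound 3, `COc1ccc(-c2nsc3c2NC(=O)CC3c2ccsc2)cc1`, differs from compound 1 by thiophen-3-yl in place of 3-methoxyphenyl on a saturated ring carbon; in this assay compound 3 gives 152 nM, a step of a 9.7-fold lower number from compound 1 to compound 3 (0.99 log units; beyond the scatter) from compound 1 and of an 8.6-fold lower number from compound 2 to compound 3 (0.93 log units; beyond the scatter) from compound 2, so that compound 3 stands with the lowest number of the three.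

Compound 4, `O=C1CC(c2ccsc2)c2snc(-c3ccc(Cl)cc3)c2N1`, has not yet been measured. It differs from compound 3 by chloro in place of methoxy on an aromatic carbon. Among the compounds with values here, this is the same kind of change as the one from compound 1 to compound 2, but not the same: there the chloro entered meta to a large group, here it enters para to a large group, and the core of compound 3 already carries the thiophen-3-yl rather than the 3-methoxyphenyl of compound 1.

Within the data shown here, the only guide to how this kind of change behaves is the step from compound 1 to compound 2, which stayed within the scatter because a 1.1-fold lower number from compound 1 to compound 2 (0.06 log units; within the scatter). On that basis the step from compound 3 to compound 4 is expected to be small as well, around a 1.1-fold higher number from compound 3 to compound 4 (0.02 log units; within the scatter). The estimate for compound 4 in this assay is therefore 160 nM, with a likely range from 60 nM to 450 nM, though a difference in the surroundings of the change leaves room for a larger move than the earlier one.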

Compound 4, half-maximal inhibitory concentration: 1080 nM
For compound 4 the middle estimate is 6.8-fold (0.83 log units) below the measured one, outside the stated range (above it).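

In this assay, chloro in place of methoxy on an aromatic carbon gives a 7.1-fold higher number from compound 3 to compound 4 (0.85 log units; beyond the scatter), so on this core the change moves the number beyond the scatter, and the methoxy that leaves is the one para to a large group, not the one replaced on the way to compound 2. Set beside the earlier step, the same kind of change does not carry over unchanged from one core to the other: the same change on two cores in this assay, a 1.1-fold lower number (0.06 log units; within the scatter) from compound 1 to compound 2 and a 7.1-fold higher number (0.85 log units; beyond the scatter) from compound 3 to compound 4, 8.1-fold (0.91 log units) apart, beyond the scatter of two such steps This shows that a step within the scatter on one compound gave no safe guide to the other, but it does not show why, since the two steps differ both in where the change falls and in the group on the saturated ring carbon, and each rests on a single pair.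

The compounds shown leave open how chloro in place of methoxy behaves at the place para to a large group when the saturated ring carbon carries 3-methoxyphenyl or 3-chlorophenyl, which would separate the effect of the place from that of the core. They also leave open whether another group at that place, such as an amine, a hydroxyl or a longer alkoxy chain, would come close to compound 3 at 152 nM.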